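The source may hold more compounds than are shown below. What is called first, only, known or untested is meant among the compounds shown, and "the series" means these compounds.

The measured compounds:
compound 1, `COC(=O)/C(=C\c1ccc(OC(=O)c2ccc(OC)cc2)cc1)Sc1ccnc2cc(Cl)ccc12`, with 11000 nM
compound 2, `COC(=O)/C(=C\c1ccc(OC(=O)c2cccc(OC)c2)cc1)Sc1ccnc2cc(Cl)ccc12`, with 33300 nM
compound 3, `COC(=O)/C(=C\c1ccc(OC(=O)c2ccccc2OC)cc1)Sc1ccnc2cc(Cl)ccc12`, with 44700 nM

All three were tested in a functional assay on Jurkat E6.1 cells (Homo sapiens) for cytotoxicity, read by MTT assay, with a stated time of 24 h; a lower number here means a stronger inhibitor, a higher number a weaker inhibitor. Compound 1 gives 11000 nM, the lowest of the three numbers. Compound 2 gives 33300 nM and stands second highest; its nearest neighbour is compound 3, which gives 44700 nM, and the step of a 1.3-fold higher number from compound 2 to compound 3 (0.13 log units; within the scatter) is within the scatter, while the step of a 3.0-fold higher number from compound 1 to compound 2 (0.48 log units; beyond the scatter) is beyond it.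

Compound 4, `COC(=O)/C(=C\c1ccc(OC(=O)c2ccc(OC)cc2OC)cc1)Sc1ccnc2cc(Cl)ccc12`, differs from compound 2 in one place: 2,4-dimethoxyphenyl in place of 3-methoxyphenyl on a carbonyl carbon. The new aryl group joins the methoxy placements of compound 1 and compound 3. The measured steps that bear on this are a 3.0-fold higher number from compound 1 to compound 2 (0.48 log units; beyond the scatter) and a 4.1-fold higher number from compound 1 to compound 3 (0.61 log units; beyond the scatter), both modest and both pointing to a higher number once the methoxy group leaves the arrangement seen in compound 1, and a 1.3-fold higher number from compound 2 to compound 3 (0.13 log units; within the scatter), which is within the scatter. Since compound 4 brings back the arrangement of compound 1 while also keeping that of compound 3, a small downward step is expected, and it may not reach beyond the scatter; the estimated step is a 1.5-fold lower number from compound 2 to compound 4 (0.18 log units; within the scatter). Compound 4 is therefore expected to give about 22000 nM in this assay, in a range from 7000 nM to 70000 nM.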

Compound 4, half-maximal inhibitory concentration: 10200 nM
Compound 4: middle estimate off by 2.2-fold (0.33 log units), on the high side; measured number inside the range.
By their numbers in this assay, from the lowest: compounds 4 and 1 (each within the scatter of the next); then compounds 2 and 3 (each within the scatter of the next).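

In this assay, methoxy in place of hydrogen on an aromatic carbon of compound 3 gives a 4.4-fold lower number from compound 3 to compound 4 (0.64 log units; beyond the scatter), and 2,4-dimethoxyphenyl in place of 3-methoxyphenyl on the carbonyl carbon gives a 3.3-fold lower number from compound 2 to compound 4 (0.51 log units; beyond the scatter), so a second methoxy group on this aryl ring can move the number beyond the scatter. The same kind of change made on compound 1 gives a 1.1-fold lower number from compound 1 to compound 4 (0.03 log units; within the scatter), which shows that the effect of adding a methoxy group at this site depends on the arrangement already present, a dependence that the three single-methoxy compounds could not show. Nothing given here explains why the added methoxy group matters on compound 3 but not on compound 1.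

The compounds shown carry only methoxy groups on this aryl ring, so it remains open whether a hydroxy group, a dimethylamino group or a chlorine atom at the same places would follow the same pattern. As far as these compounds go, it is also open whether the 2,4-dimethoxyphenyl group would behave the same way with a carboxylic acid in place of the methyl ester on the shared core.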